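The source may report more compounds than this note shows. Statements on the series, on what has been measured and on what is new or still open speak of the compounds shown alone.

Working notes on the series.

The series shares one core, seen in compound 1 `c1ccc(C(c2ccncc2)N2CCN(c3ncnc4c3cnn4-c3ccccc3)CC2)cc1` and in compound 2 `Cc1ccsc1C(c1c(C)noc1C)N1CCN(c2ncnc3c2cnn3-c2ccccc2)CC1`. Both have been run in a functional assay on cells (Rhabdomyosarcoma cell, Homo sapiens) for cytotoxicity; a lower number here means a stronger inhibitor, a higher number a weaker inhibitor.

In this assay compound 1 gives > 25000 nM, which is a limit of the assay and not a number. In this assay compound 2 gives > 25000 nM, again a limit rather than a number. Going by the values given here, compound 1 therefore stands at the limit, and the one further value shown sits there as well: the limit of > 25000 nM in this assay, at which 2 of the 2 values shown sit. Among the compounds with values here, no step between measured compounds can be counted, since neither value is a number.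

The compound to be measured next is compound 3 `c1ccc(C(c2ccccc2)N2CCN(c3ncnc4c3cnn4-c3ccccc3)CC2)cc1`. It differs from compound 1 in one place: phenyl in place of pyridin-4-yl on a saturated chain carbon bound to an amine nitrogen in a ring and an aromatic carbon.

With both measured compounds at the limit, no direction of change in this assay can be read from the data. The step from compound 1 to compound 3 is expected to be none beyond the scatter, as a step that the limit leaves unreadable from compound 1 to compound 3 expresses it. Compound 3 is accordingly expected to give about 30000 nM in this assay, within 10000 nM to 100000 nM, and most likely to be reported only as a limit.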

Compound 3, half-maximal inhibitory concentration: > 25000 nM
Compound 3 was reported as a limit (the forecaster's own chance of this, stated with the estimate: 80%); the middle value lies beyond the limit too.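

Going by these compounds alone, no step from compound 1 to compound 3 can be read in this assay, since both values are limits of the assay and not numbers: the limit of > 25000 nM in this assay, at which 3 of the 3 values shown sit.

The compounds shown leave open how phenyl and pyridin-4-yl compare at this place, and whether any compound on the shared core gives a measurable value in this assay at all.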